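Replacing the methyl oxadiazole of compound 2

A few compounds are considered here, and "the series" means these few. Any claim that something is new, unique, unknown or untested is made for them only; others in the source may bear on it.

Compound 1 `N#Cc1ccc(N2CCC(C(=O)N3N=CC[C@H]3c3cc(F)cc(F)c3)CC2)nn1`: 4.8
Compound 2 `Cc1nnc(N2CCC(C(=O)N3N=CC[C@H]3c3cc(F)cc(F)c3)CC2)o1`: 3.6

In a physicochemical assay for lipophilicity, read by HPLC, measured as chromatographic lipophilicity, at pH 7.4 (on this read-out lower numbers stand for lower lipophilicity and higher numbers for higher lipophilicity), compound 2 stands at 3.6 as the lower of the two numbers. Compound 3 `N#Cc1nccc(N2CCC(C(=O)N3N=CC[C@H]3c3cc(F)cc(F)c3)CC2)n1` brings 2-cyanopyrimidin-4-yl in place of 5-methyl-1,3,4-oxadiazol-2-yl on an amine nitrogen in a ring with 2-cyanopyrimidin-4-yl in place of 5-methyl-1,3,4-oxadiazol-2-yl on an amine nitrogen in a ring. For the measured compounds named here, only one measured step bears on this: the large a number 1.20 log units lower from compound 1 to compound 2 (beyond the scatter) in a swap running the opposite way. The entering group resembles that of compound 1 without being identical. A large rise is therefore expected, with a number 1.00 log units higher from compound 2 to compound 3 (beyond the scatter) as the estimated step. The estimate for compound 3 is 4.6 within an expected range of 4 to 5.1 on this reasoning.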

Compound 3, distribution coefficient: 5.1
Estimate against measurement, compound 3: 0.50 log units below, and the stated range covers the measured number.
By their numbers in this assay, from the lowest: compound 2; then compounds 1 and 3 (each within the scatter of the next).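

In this assay, 2-cyanopyrimidin-4-yl on the amine nitrogen gives a number 1.50 log units higher from compound 2 to compound 3 (beyond the scatter), so the large gap seen with the group of compound 1 also appears with a second six-membered aromatic ring bearing a nitrile. These two eight-atom groups cannot be told apart here: a number 0.30 log units higher from compound 1 to compound 3 (within the scatter). Nothing measured here explains the size of these steps. Still open, from the compounds shown here alone, is where this assay would place such a ring carrying an amine or a carboxylic acid in place of the nitrile.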